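Three Cinnamamides and a Trifluorophenyl Successor

The compounds below may be only part of what the source reports. "The series", "measured", "known", "first", "only" and "open" are said of these compounds alone.

The measured compounds:
Compound 1, `COc1ccc(/C=C/C(=O)Nc2cc(C(=O)c3cc(OC)c(OC)c(OC)c3)cc(OC)c2OC)cc1`: 10400 nM
Compound 2, `COc1cc(C(=O)c2cc(OC)c(OC)c(OC)c2)cc(NC(=O)/C=C/c2ccc(F)cc2)c1OC`: 6700 nM
Compound 3, `COc1cc(C(=O)c2cc(OC)c(OC)c(OC)c2)cc(NC(=O)/C=C/c2ccc(C(F)(F)F)cc2)c1OC`: 5100 nM

All three were tested in a functional assay on DU-145 cells (Homo sapiens) for cytotoxicity, read by MTT assay, with a stated time of 72 h; a lower number here means a stronger inhibitor, a higher number a weaker inhibitor. Compound 3 stands at the low end of the three numbers: the step of a 2.0-fold lower number from compound 1 to compound 3 (0.31 log units; beyond the scatter) is a modest one beyond the scatter, whereas compound 2 sits within the scatter of compound 3, since a 1.3-fold lower number from compound 2 to compound 3 (0.12 log units; within the scatter). The step of a 1.6-fold lower number from compound 1 to compound 2 (0.19 log units; within the scatter) is likewise within the scatter.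

Compound 4, `COc1cc(C(=O)c2cc(OC)c(OC)c(OC)c2)cc(NC(=O)/C=C/c2cc(F)c(F)c(F)c2)c1OC`, has not been measured. It differs from compound 3 in one place: 3,4,5-trifluorophenyl in place of 4-(trifluoromethyl)phenyl on a double-bonded chain carbon bound to a double-bonded chain carbon. Within the data shown here, the only measured step that bears on fluoro against trifluoromethyl is a 1.3-fold lower number from compound 2 to compound 3 (0.12 log units; within the scatter), which is small. Among the measured compounds shown here, no measured pair speaks to the two added fluoro groups. From this the step of a 1.0-fold lower number from compound 3 to compound 4 (0.01 log units; within the scatter) is expected to stay within the scatter, with no clear direction. Compound 4 is therefore estimated to give 5000 nM in this assay, with a range from 2500 nM to 12000 nM.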

Compound 4, half-maximal inhibitory concentration: 7900 nM
Beside the measured number, compound 4's estimate is 1.6-fold (0.20 log units) below it; measured number inside the range.
By their numbers in this assay, from the lowest: compounds 3, 2, 4 and 1 (each within the scatter of the next, the first and the last beyond it).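

In this assay, 3,4,5-trifluorophenyl on this double-bonded chain carbon gives no step beyond the scatter against any of the three earlier end groups (4-(trifluoromethyl)phenyl: a 1.5-fold higher number from compound 3 to compound 4 (0.19 log units; within the scatter)) (4-fluorophenyl: a 1.2-fold higher number from compound 2 to compound 4 (0.07 log units; within the scatter)) (4-methoxyphenyl: a 1.3-fold lower number from compound 1 to compound 4 (0.12 log units; within the scatter)). The earlier compounds shown here compared only 4-substituted phenyl groups, whereas this result shows that an end group with three fluoro substituents on the ring also stays within the scatter of both fluorinated compounds and of compound 1. Nothing available here gives a reason for this result.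

The compounds shown leave open whether an amine or a carboxylic acid on this phenyl ring would produce a larger step. They also leave open whether a longer chain in place of the double-bonded chain would do so.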